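The source may hold more compounds than are shown below. What is called first, only, known or untested is meant among the compounds shown, and "the series" means these compounds.

In a functional assay on HO8910 cells (Homo sapiens) for inhibition, read by MTT assay, with a stated time of 24 h, tested at 1 ug/mL (a lower number here means less inhibition of growth, a higher number more inhibition of growth at the concentration tested), compound 1 (`O=C(O)CCCCC(CCSC(=O)c1ccccc1)SC(=O)c1ccccc1`) gives 0.29% and compound 2 (`O=C(CCCCC(CCSC(=O)c1ccccc1)SC(=O)c1ccccc1)Nc1ccccc1Cl`) gives 2.35% with the two lying within the scatter of each other. Compound 3 (`O=C(CCCCC(CCSC(=O)c1ccccc1)SC(=O)c1ccccc1)Nc1cccc(Cl)c1`) differs from compound 2 by one exchange (3-chlorophenyl in place of 2-chlorophenyl on an amide-type nitrogen) in which 3-chlorophenyl takes the place of 2-chlorophenyl on an amide-type nitrogen. Within the data shown here, the only measured step (a number 2.1 percentage points higher from compound 1 to compound 2 (within the scatter)) put (2-chlorophenyl)amino in place of hydroxy and stayed small, and no measurement yet compares the two chlorophenyl groups. No step beyond the scatter is therefore expected in this assay for this exchange. The estimated step (a number 0.7 percentage points higher from compound 2 to compound 3 (within the scatter)) is small. Compound 3 is expected at 3% within an estimated range (0% to 12%).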

Compound 3, percent growth inhibition at one concentration: 3.38%
Estimate against measurement, compound 3: 0.4 percentage points below, and the stated range covers the measured number.
By their numbers in this assay, from the lowest: compounds 1, 2 and 3 (each within the scatter of the next).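

In this assay, among these compounds, the first direct comparison of the two chlorophenyl groups on the amide-type nitrogen gives a number 1 percentage points higher from compound 2 to compound 3 (within the scatter), so the data do not separate 3-chlorophenyl from 2-chlorophenyl at this place. Putting (3-chlorophenyl)amino in place of hydroxy on the carbonyl carbon gives a number 3.1 percentage points higher from compound 1 to compound 3 (within the scatter), so compound 3, like compound 2, cannot be told apart from compound 1. No supporting data are available to explain these numbers. As far as these compounds go, what a cyclohexyl group or a pyridine ring on the amide-type nitrogen would give remains open.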